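A Chlorophenyl Amide Swap: Forecast for Compound 4

A few compounds are considered here, and "the series" means these few. Any claim that something is new, unique, unknown or untested is made for them only; others in the source may bear on it.

compound 1, `COc1cc2c(cc1OC)C(CC(=O)O)CC2`: 24%
compound 2, `COc1cc2c(cc1OC)C(CC(=O)Nc1ccccc1)CC2`: 32%
compound 3, `COc1cc2c(cc1OC)C(CC(=O)Nc1cccc(Cl)c1)CC2`: 28%

Within the data shown here, in a functional assay on the whole organism (strain Wistar) for inhibition, with Rattus norvegicus as the target, read by paw edema, with a stated time of 2 h, at a dose of 100 mg/kg (on this read-out higher numbers stand for more inhibition at the one dose given (going by the name of the read-out) and lower numbers for less inhibition), compound 3 stands second highest of the three numbers measured so far. Its nearest neighbour is compound 1, a number 4 percentage points higher from compound 1 to compound 3 (within the scatter); the other neighbour is compound 2, a number 4 percentage points lower from compound 2 to compound 3 (within the scatter). Both gaps lie within the scatter, so none of the three is separated from the others.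

Compound 4, `COc1cc2c(cc1OC)C(CC(=O)Nc1ccc(Cl)cc1)CC2`, differs from compound 3 in one place: 4-chlorophenyl in place of 3-chlorophenyl on an amide-type nitrogen.

Among the measured compounds shown here, three measured steps bear on this change. Replacing hydroxy on the carbonyl carbon by anilino gave a number 8 percentage points higher from compound 1 to compound 2 (within the scatter), and by (3-chlorophenyl)amino gave a number 4 percentage points higher from compound 1 to compound 3 (within the scatter); adding chloro in place of hydrogen on the aromatic carbon of the anilino group gave a number 4 percentage points lower from compound 2 to compound 3 (within the scatter). For the measured compounds named here, every one of these lies within the scatter, and no measured pair tells whether a 4-chlorophenyl differs from a 3-chlorophenyl here.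

Compound 4 is therefore expected to show no step beyond the scatter, a number 1 percentage points higher from compound 3 to compound 4 (within the scatter), and its estimated value is 29%, expected to fall between 17% and 41%.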

Compound 4, a percentage reported as inhibition, in the whole organism at one dose (the size of the read-out at that dose, not a potency): 63%
The estimate for compound 4 lay 34 percentage points below the measured number, outside the stated range (above it).
By their numbers in this assay, from the lowest: compounds 1, 3 and 2 (each within the scatter of the next); then compound 4.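

In this assay, among these compounds, the chloro group's place on the ring proves decisive: 4-chlorophenyl in place of 3-chlorophenyl on the amide-type nitrogen, with the same atoms joined differently, gives a number 35 percentage points higher from compound 3 to compound 4 (beyond the scatter) and separates a compound from the others for the first time. Chloro in place of hydrogen on an aromatic carbon now gives a number 31 percentage points higher from compound 2 to compound 4 (beyond the scatter) where the other chloro isomer gave only a number 4 percentage points lower from compound 2 to compound 3 (within the scatter) and so the effect of adding chloro depends on where it sits, while (4-chlorophenyl)amino in place of hydroxy on the carbonyl carbon gives a number 39 percentage points higher from compound 1 to compound 4 (beyond the scatter) as the only replacement of hydroxy that clears the scatter. Nothing available explains this difference between the two isomers.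

On these data alone, whether the gain needs chlorine itself remains open, as 4-fluorophenyl, 4-methylphenyl or 4-methoxyphenyl on the same nitrogen would test. Whether it would survive a longer chain between the shared core and the carbonyl is also unanswered.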